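This account rests on a few compounds, and the source may have more. Where it says the series, first, only, none or still open, it means among the compounds named here.

Measured so far in a functional assay on SK-HEP1 cells (Homo sapiens) for antiproliferative activity, read by sulforhodamine B assay; a higher number here means a weaker inhibitor of growth, a lower number a stronger inhibitor of growth:
- compound 1 `Cc1ccc(C(=O)Nc2nc3cc(C)cc(C)c3s2)cc1`: 2.17 ug/mL
- compound 2 `COc1ccc2sc(NC(=O)c3ccc(C(F)(F)F)cc3)nc2c1`: > 10 ug/mL

Compound 2 stands at the limit of > 10 ug/mL in this assay, at which 1 of the 2 values shown sits; this is a limit of the assay, not a number. Compound 3 `COc1ccc2sc(NC(=O)c3ccc(C#N)cc3)nc2c1` differs from compound 2 in one place: cyano in place of trifluoromethyl on an aromatic carbon. Among the measured compounds shown here, no measured pair shows this change, so its size is open. The step of a number no higher from compound 2 to compound 3 (the limit leaves the size open) is expected to be small, with no direction beyond the scatter, since compound 2 itself gives only a limit in this assay. Compound 3 is therefore expected near 10 ug/mL, estimated between 3 ug/mL and 30 ug/mL, with a fair chance that again only a limit is reported.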

Compound 3, concentration for 50% growth inhibition: > 10 ug/mL
Compound 3 gave a limit, no number (the forecaster's own chance of this, stated with the estimate: 55%); the middle value sits exactly at the limit.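

Compound 2 and compound 3 each give only a limit, not a number, in this assay, so no step can be read between them: the limit of > 10 ug/mL in this assay, at which 2 of the 3 values shown sit.

Going by these compounds, whether cyano in place of trifluoromethyl changes growth inhibition at all remains open.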